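Flipping the Methyl's Configuration: Compound 3

The source may report more compounds than this note shows. Statements on the series, on what has been measured and on what is new or still open speak of the compounds shown alone.

Compound 1 `CC[C@H]1CN(c2ncc(C(N)=O)nc2C)CCN1C1CCN(C(=O)c2ccc(Cl)cc2)CC1` gives 18 nM in an in vitro assay on BaF3 cells for displacement of a labelled ligand from C-X-C chemokine receptor type 3 (Homo sapiens); a higher number here means a weaker inhibitor, a lower number a stronger inhibitor. Adding a methyl on a saturated ring carbon gives compound 2 `CC[C@H]1CN(c2ncc(C(N)=O)nc2C)[C@H](C)CN1C1CCN(C(=O)c2ccc(Cl)cc2)CC1`, which in this assay gives 5.4 nM and stands lowest of the two numbers; that step is a 3.3-fold lower number from compound 1 to compound 2 (0.52 log units; beyond the scatter). Compound 3 `CC[C@H]1CN(c2ncc(C(N)=O)nc2C)[C@@H](C)CN1C1CCN(C(=O)c2ccc(Cl)cc2)CC1` keeps every atom of compound 2 and differs only in configuration: the two compounds have the same atoms and bonds and differ only in configuration as drawn: 1 of 2 stereo elements differ; a stereocentre at a saturated ring carbon is drawn R in compound 2 and S in compound 3. Among the compounds with values here, no measured step tests a change of configuration, so the only step bears on it indirectly: the gain seen with the methyl need not carry over to its mirror placement. For compound 3 a modest rise in this assay is expected, a 3.7-fold higher number from compound 2 to compound 3 (0.57 log units; beyond the scatter). Compound 3 is estimated at 20 nM, within 6 nM to 70 nM.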

Compound 3, half-maximal inhibitory concentration: > 1000 nM
Compound 3: only a limit was reported (the forecaster's own chance of this, stated with the estimate: 3%); at least 50-fold (1.69 log units) between middle value and limit.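

Compound 3 gives only a limit in this assay of > 1000 nM and no exact number. At this ring carbon the methyl's configuration decides the outcome: the step is an at least 180-fold higher number from compound 2 to compound 3 (2.26 log units; beyond the scatter) and, against the compound without the methyl, an at least 55-fold higher number from compound 1 to compound 3 (1.74 log units; beyond the scatter) so the same group that lowered the number in one configuration raises it in the other. That swing comes from configuration alone: the fact that compounds 2 and 3 differ only in the configuration as drawn.

On these data alone, how far the true value of compound 3 lies past its limit remains open. So does whether a hydroxymethyl group at this carbon would show the same dependence on configuration.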